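The source may hold more compounds than are shown below. What is called first, only, known or untested is meant among the compounds shown, and "the series" means these compounds.

In an ADME assay on microsomes (Rattus norvegicus) for metabolic stability (on this read-out higher numbers stand for a longer-lived compound and lower numbers for a shorter-lived compound), compound 1 `CC[C@@H]1NC(=O)[C@H](CCCNC(=N)N)NC(=O)[C@](C)(NC(=O)C(C)C)CCCCN(C)C(=O)[C@@H](c2ccc(Cl)cc2)NC1=O` gives > 1 h as a limit and not a number. Compound 2 `CC[C@@H]1NC(=O)[C@H](CCCNC(=N)N)NC(=O)[C@](C)(NC(=O)C(C)C)CCCCN(C)C(=O)[C@@H](c2ccccc2)NC1=O` likewise gives > 1 h as a limit and not a number. Among the measured compounds shown here, the single measured change, hydrogen in place of chloro on an aromatic carbon, is a step that the two limits leave unreadable from compound 1 to compound 2 and yields no size. The scale so far offers only the limit of > 1 h in this assay, at which 2 of the 2 values shown sit, and no true number, so compound 2 stands at a limit and nowhere more exact.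

Compound 3 `CC[C@@H]1NC(=O)[C@H](CCCNC(=N)N)NC(=O)[C@](C)(NC(=O)C(C)C)CCCCNC(=O)[C@@H](c2ccccc2)NC1=O` departs from compound 2 by hydrogen in place of methyl on an amide-type nitrogen in a ring in one place, with hydrogen in place of methyl on an amide-type nitrogen in a ring. For the measured compounds named here, no measured step touches that nitrogen, so the data support no particular size or direction in this assay and no move beyond the scatter can be argued. Going by the values given here, the only anchor is compound 2 with its > 1 h as a limit. The expected move is a step that the limit leaves unreadable from compound 2 to compound 3 and it remains only an estimate. Compound 3 is estimated at 1.2 h with an expected range from 0.5 h to 3 h. The outcome for compound 3 may again be only a limit.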

Compound 3, half-life: > 1 h
Compound 3 gave a limit, no number (the forecaster's own chance of this, stated with the estimate: 60%); the middle value lies beyond the limit too.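

Among the compounds shown here, neither the step from compound 1 to compound 2 nor the one from compound 2 to compound 3 can be read in this assay, as both ends of each are limits and not numbers. The compounds shown leave open the true half-life of each compound, and so whether either change moves it at all: the limit of > 1 h in this assay, at which 3 of the 3 values shown sit.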